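The source may hold more compounds than are shown below. What is called first, only, known or untested is meant among the compounds shown, and "the series" means these compounds.

Compound 1 `COc1ccccc1/C=C/C(=O)c1ccc(OCC(=O)N[C@H]2CCOC2=O)cc1` is one of three compounds tested for their ability to slow the growth of prostate cancer cells. In a functional assay on DU-145 cells (Homo sapiens) for antiproliferative activity, read by MTT assay, with a stated time of 72 h (on this read-out higher numbers stand for weaker inhibition and lower numbers for stronger inhibition), compound 1 gives 10100 nM. Compound 2 `Cc1cc(Cl)ccc1NCC(=O)N[C@H]1CCOC1=O` gives > 64000 nM, which is a limit of this assay rather than a number. Compound 3 `O=C1OCC[C@@H]1NC(=S)SCCOc1ccc(Cl)cc1` gives > 64000 nM, again a limit and not a number. Among the measured compounds shown here, compound 1 thus holds the only actual number among the three. Two of the three readings stand at the limit of > 64000 nM in this assay, at which 2 of the 3 values shown sit. Compound 4 `O=C(COc1ccc(C(=O)/C=C/c2ccc(F)cc2)cc1)N[C@H]1CCOC1=O` keeps the core of compound 1 and differs in one place (4-fluorophenyl in place of 2-methoxyphenyl on a double-bonded chain carbon bound to a double-bonded chain carbon). For the measured compounds named here, no measured pair of compounds shows the effect of such a swap, so the expected step of a 1.4-fold lower number from compound 1 to compound 4 (0.16 log units; within the scatter) is small, within the scatter. Compound 4 is therefore estimated at 7000 nM, with a likely range from 2500 nM to 20000 nM.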

Compound 4, half-maximal inhibitory concentration: 18800 nM
Estimate against measurement, compound 4: 2.7-fold (0.43 log units) below, within the range that was stated.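

In this assay, among the compounds shown here, the change to 4-fluorophenyl in place of 2-methoxyphenyl gives a 1.9-fold higher number from compound 1 to compound 4 (0.27 log units; within the scatter) as the first measured step at this place on the chain. Compound 1 and compound 4 therefore cannot be told apart here, so this exchange of one substituted phenyl for another leaves activity within the usual scatter. Nothing measured here accounts for the step. Still open, as far as these compounds go, is how a plain phenyl would compare with these two groups. Also open, from the compounds shown here alone, is whether an amine or a carboxylic acid on that phenyl would move the number beyond the scatter.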